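Swapping the anilino aryl group in compound 3

The source may hold more compounds than are shown below. What is called first, only, known or untested is meant among the compounds shown, and "the series" means these compounds.

Measured so far in a functional assay on SAOS-2 cells (Homo sapiens) for antiproliferative activity, read by MTT assay, with a stated time of 72 h; a higher number here means a weaker inhibitor, a lower number a stronger inhibitor:
compound 1 `CCOC1=C(C(=O)c2ccccc2)C(c2ccc(Br)cc2)N(CCCn2ccnc2)C1=O` gives 31700 nM
compound 2 `CCCCOC1=C(C(=O)c2ccccc2)C(c2ccc(Br)cc2)N(CCCn2ccnc2)C1=O` gives 11600 nM
compound 3 `O=C(C1=C(Nc2ccc(I)cc2)C(=O)N(CCCn2ccnc2)C1c1ccc(Br)cc1)c1ccccc1` gives 23400 nM

Compound 3 sits close to the other two numbers. Its nearest neighbour is compound 1, with a gap of a 1.4-fold lower number from compound 1 to compound 3 (0.13 log units; within the scatter), and the other gap is a 2.0-fold higher number from compound 2 to compound 3 (0.30 log units; within the scatter). The one step among these three that lies beyond the scatter is a 2.7-fold lower number from compound 1 to compound 2 (0.44 log units; beyond the scatter), and that step concerns the alkoxy chain, not the anilino side of the core.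

Compound 4 `O=C(C1=C(Nc2cccc(Br)c2)C(=O)N(CCCn2ccnc2)C1c1ccc(Br)cc1)c1ccccc1` differs from compound 3 in one place: 3-bromophenyl in place of 4-iodophenyl on an amine nitrogen. Going by the values given here, none of the measured steps touches the aryl group on that amine nitrogen. The two steps that reach the anilino group at all, from compound 1 and from compound 2 to compound 3, replace an alkoxy group by the (4-iodophenyl)amino group and both stay within the scatter. There is thus no measured ground for expecting movement in this assay in either direction, and the expectation is a step of no more than the scatter. Compound 4 is accordingly estimated at 24000 nM, with a range from 10000 nM to 60000 nM. The step this estimate implies is a 1.0-fold higher number from compound 3 to compound 4 (0.01 log units; within the scatter), expected to stay within the scatter.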

Compound 4, half-maximal inhibitory concentration: 9090 nM
Beside the measured number, compound 4's estimate is 2.6-fold (0.42 log units) above it; measured number outside the range, below it.
By their numbers in this assay, from the lowest: compounds 4, 2, 3 and 1 (each within the scatter of the next, the first and the last beyond it).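

In this assay, going by these compounds alone, the aryl group on the amine nitrogen proves able to move the number: 3-bromophenyl in place of 4-iodophenyl gives the step (a 2.6-fold lower number from compound 3 to compound 4 (0.41 log units; beyond the scatter)), the first measured change on this side of the core to go beyond the scatter. The (3-bromophenyl)amino group also separates from ethoxy (a 3.5-fold lower number from compound 1 to compound 4 (0.54 log units; beyond the scatter)), which the (4-iodophenyl)amino group did not do, while it cannot be told apart from butoxy (a 1.3-fold lower number from compound 2 to compound 4 (0.11 log units; within the scatter)). Nothing available on these compounds accounts for the step at the amine nitrogen.

This single change alters both the halogen and its place on the aryl group, so compound 3 and compound 4 cannot show which of the two carries the step; 4-bromophenyl or 3-iodophenyl would separate them. The compounds shown also leave open how this position would respond to an unsubstituted phenyl, 3-chlorophenyl or 3-methoxyphenyl group, and whether any such group would go further than 3-bromophenyl in this assay.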